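From ethyl to 4-hydroxycyclohexyl at a stability limit

A few compounds are considered here, and "the series" means these few. Any claim that something is new, unique, unknown or untested is made for them only; others in the source may bear on it.

Compounds measured so far in an in vitro ADME assay on microsomes (Mus musculus) for metabolic stability; on this read-out higher numbers stand for a longer-lived compound and lower numbers for a shorter-lived compound:
Compound 1 `CNC(=O)Nc1ccc(-c2nc(N3CC4CCC(C3)O4)c3cnn(C(C)C)c3n2)cc1`: > 0.5 h (a limit)
Compound 2 `CCn1ncc2c(N3CC4CCC(C3)O4)nc(-c3ccc(NC(=O)NC)cc3)nc21`: > 0.5 h (a limit)

In this assay compound 2 reads > 0.5 h and this is a limit, not a number. Going by the values given here, compound 1 likewise gives only a limit, > 0.5 h as its sole reading. So compound 2 has no exact place on the scale and shares the limit of > 0.5 h in this assay, at which 2 of the 2 values shown sit, with the only other compound tested.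

Compound 3 `CNC(=O)Nc1ccc(-c2nc(N3CC4CCC(C3)O4)c3cnn([C@H]4CC[C@H](O)CC4)c3n2)cc1` keeps the shared core of compound 2 and has not yet been measured. It carries 4-hydroxycyclohexyl in place of ethyl on an aromatic nitrogen and this is a far larger change than the one measured so far. Among the compounds with values here, the only measured step at that nitrogen is a step that the two limits leave unreadable from compound 1 to compound 2 and it offers no size to carry over. No step beyond the scatter is therefore expected in this assay and no direction can be favoured. The expected step is a step that the limit leaves unreadable from compound 2 to compound 3 and it remains a cautious estimate. Compound 3 is estimated at 0.6 h with an expected range from 0.3 h to 1.2 h and the assay may again report only a limit.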

Compound 3, half-life: > 0.5 h
Compound 3 was reported as a limit; the forecaster's own chance of this, stated with the estimate: 60%; the middle value does not contradict the limit.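

In this assay compound 3 gives > 0.5 h, which is a limit and not a number. Its steps from compound 1 and compound 2 cannot be read, and all three compounds stand together: the limit of > 0.5 h in this assay, at which 3 of the 3 values shown sit. The compounds shown leave open the actual half-lives in this assay and whether ethyl, isopropyl or 4-hydroxycyclohexyl on the aromatic nitrogen makes any difference.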